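The source may hold more compounds than are shown below. What is called first, only, known or untested is meant among the compounds shown, and "the series" means these compounds.

Measured so far in a functional assay on CHO cells for agonist activity at Free fatty acid receptor 1 (Homo sapiens), read by calcium flux; on this read-out higher numbers stand for an effect only at larger amounts of compound and lower numbers for an effect already at smaller amounts:

Compound 1, `O=C(O)CCc1nnc(C(=O)Nc2cccc(-c3cccc(Cl)c3)c2)s1`: 1690 nM
Compound 2, `O=C(O)CCc1nnc(C(=O)Nc2cccc(-c3ccc(F)cc3)c2)s1`: 1280 nM
Compound 3, `COc1ccc(NC(=O)c2nnc(COc3ccc(CCC(=O)O)cc3)s2)cc1`: > 10000 nM

Going by the values given here, compounds 1 and 2 share one arrangement of the core and differ only in the aryl group on an aromatic carbon; the step of a 1.3-fold lower number from compound 1 to compound 2 (0.12 log units; within the scatter) is the single measured step in this set. Compound 3 carries a different arrangement of the core, and for compound 3 this assay reports only a limit, > 10000 nM, which is the limit named in the limit of > 10000 nM in this assay, at which 1 of the 3 values shown sits, rather than a number.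

Compound 4, `Cc1cccc(NC(=O)c2nnc(COc3ccc(CCC(=O)O)cc3)s2)c1`, differs from compound 3 by 3-methylphenyl in place of 4-methoxyphenyl on an amide-type nitrogen. Among the compounds with values here, no measured step touches this position; the only measured step, a 1.3-fold lower number from compound 1 to compound 2 (0.12 log units; within the scatter), exchanges one aryl group for another at a different place and lies within the scatter. With compound 3 sitting at the limit, compound 4 is expected to behave much the same. The expected step, a step that the limit leaves unreadable from compound 3 to compound 4, is estimated to be no change beyond the scatter. Compound 4 is therefore estimated at 15000 nM, within a range from 4000 nM to 50000 nM, and most likely again reported only as a limit.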

Compound 4, half-maximal effective concentration: 1770 nM
For compound 4 the middle estimate is 8.5-fold (0.93 log units) above the measured one; the whole stated range lies above it.
By their numbers in this assay, from the lowest: compounds 2, 1 and 4 (each within the scatter of the next). At a limit, above all of these: compound 3.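

In this assay, going by these compounds alone, replacing 4-methoxyphenyl with 3-methylphenyl on the amide-type nitrogen gives an at least 5.6-fold lower number from compound 3 to compound 4 (0.75 log units; beyond the scatter), which shows that this position, untouched by the one earlier step, does respond to change. Compound 4 keeps the arrangement of the core found in compound 3, so that arrangement alone does not hold a compound at the limit. The step gives only a lower bound on the size of the change, and its full size cannot be read, since the value of compound 3 is a limit and not a number: the limit of > 10000 nM in this assay, at which 1 of the 4 values shown sits.

The compounds shown leave open whether the difference follows from methoxy against methyl or from where the group sits, since both change together in this step. A 3-methoxyphenyl or a 4-methylphenyl on the same amide-type nitrogen would separate the two.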